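The source may hold more compounds than are shown below. What is called first, only, known or untested is meant among the compounds shown, and "the series" means these compounds.

Three compounds share one core and differ only in the group carried on the saturated chain carbon that is bound to an oxygen on a saturated carbon. In a functional assay on HEK293 cells for agonist activity at G-protein coupled receptor 39 (Homo sapiens), read by scintillation proximity assay and inositol phosphate accumulation, with a stated time of 75 min (on this read-out higher numbers stand for an effect only at larger amounts of compound and lower numbers for an effect already at smaller amounts), compound 1 `Cc1nn(-c2ncnc3nc[nH]c23)c2c1C(OCc1cc(F)cc3c1OCOC3)CC(=O)N2` gives 30 nM. Compound 2 `Cc1nn(-c2ncnc3nc[nH]c23)c2c1C(OCc1ccc(C(C)C)cc1)CC(=O)N2` gives 1690 nM in this assay, and compound 3 `Cc1nn(-c2ncnc3nc[nH]c23)c2c1C(OCc1ccccc1Cl)CC(=O)N2` gives 47 nM. Compound 3 thus stands second highest of the three numbers: its nearest neighbour is compound 1, as a 1.6-fold higher number from compound 1 to compound 3 (0.19 log units; within the scatter) shows, and its furthest is compound 2, as a 36-fold lower number from compound 2 to compound 3 (1.56 log units; beyond the scatter) shows; the remaining comparison is a 56-fold higher number from compound 1 to compound 2 (1.75 log units; beyond the scatter).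

Compound 4 `Cc1nn(-c2ncnc3nc[nH]c23)c2c1C(OCc1ccccc1F)CC(=O)N2` is the next member. Its difference from compound 3 is fluoro in place of chloro on an aromatic carbon. Among the compounds with values here, no measured step exchanges one halogen for another on the same aromatic carbon; the two large steps both involve the 4-isopropylphenyl group of compound 2, and the step from compound 1 to compound 3 stays within the scatter even though the whole group changes. Nothing seen here therefore points to a shift beyond the scatter, and the expected step is a 1.3-fold higher number from compound 3 to compound 4 (0.11 log units; within the scatter). Compound 4 is estimated to give 60 nM in this assay, with an expected range from 20 nM to 180 nM.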

Compound 4, half-maximal effective concentration: 78 nM
Beside the measured number, compound 4's estimate is 1.3-fold (0.11 log units) below it; the measured number falls inside the stated range.
By their numbers in this assay, from the lowest: compounds 1, 3 and 4 (each within the scatter of the next, the first and the last beyond it); then compound 2.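

In this assay, within the data shown here, the first direct exchange of one halogen for another, on an aromatic carbon ortho to a large group, gives a 1.7-fold higher number from compound 3 to compound 4 (0.22 log units; within the scatter), so chloro and fluoro cannot be told apart at this place. The 2-fluorophenyl group stays far from the 4-isopropylphenyl group, with a 22-fold lower number from compound 2 to compound 4 (1.34 log units; beyond the scatter), so the large gap first seen with compound 3 also appears with a second halogen. The comparison with the larger group of compound 1 now gives a 2.6-fold higher number from compound 1 to compound 4 (0.41 log units; beyond the scatter), a modest gap beyond the scatter that compound 3 did not show, even though compound 3 and compound 4 lie within the scatter of each other, and no information at hand bears on the reason for any of these differences.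

Going by these compounds, how a bromo group, a methyl group or an amine on the same aromatic carbon would read remains open, as does a plain phenyl group with no halogen. Compound 2 differs from compound 4 in both the group and its place on the ring, so the compounds shown do not separate the effect of the isopropyl group from that of its place.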